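Acetyl on a side-chain oxygen in a weakly active series

The source may report more compounds than this note shows. Statements on the series, on what has been measured and on what is new or still open speak of the compounds shown alone.

All values below come from a functional assay on RAW264.7 cells (Mus musculus) for inhibition, read by Griess assay, with a stated time of 18 h; on this read-out lower numbers stand for stronger inhibition and higher numbers for weaker inhibition.

compound 1, `O=C(O)O[C@H](C[C@@H](O)C[C@H]1CC=CC(=O)O1)C[C@H](O)/C=C/c1ccccc1`: > 50000 nM, a limit of the assay
compound 2, `CC(=O)O[C@H](C[C@H](C[C@H](O)/C=C/c1ccccc1)OC(=O)O)C[C@H]1CC=CC(=O)O1`: > 50000 nM, a limit of the assay
compound 3, `O=C1C=C[C@H](O)[C@H](C[C@H](O)C[C@@H](O)C[C@H](O)/C=C/c2ccccc2)O1`: 13800 nM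

Among the measured compounds shown here, compound 3 is the only member with a number in this assay. Compound 1 gives only a limit. Compound 2 likewise gives only a limit. The change from compound 1 to compound 2 is acetyl in place of hydrogen on an oxygen on a saturated carbon. In this assay the step that the two limits leave unreadable from compound 1 to compound 2 cannot be sized because the limit of > 50000 nM in this assay, at which 2 of the 3 values shown sit, holds both ends of it.

Compound 4, `CC(=O)O[C@H](C[C@@H](O)C[C@H](O)/C=C/c1ccccc1)C[C@@H]1OC(=O)C=C[C@@H]1O`, is not yet measured. It differs from compound 3 by acetyl in place of hydrogen on an oxygen on a saturated carbon, the same change as that from compound 1 to compound 2, at a place described in the same words. How the core of compound 3 differs from that of compound 1 is not broken down here.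

Since the earlier instance of this change left no readable step, the expectation for compound 4 rests on the value of compound 3, 13800 nM, and the step from compound 3 to compound 4 is expected to be a 1.4-fold higher number from compound 3 to compound 4 (0.16 log units; within the scatter), within the usual scatter. Compound 4 is therefore estimated at 20000 nM, with a range from 7000 nM to 60000 nM; a limit rather than a number is a real possibility.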

Compound 4, half-maximal inhibitory concentration: 27600 nM
The estimate for compound 4 lay 1.4-fold (0.14 log units) below the measured number; low and high end bracket the measured number.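

On the core of compound 3, hydroxy to acetoxy gives a 2.0-fold higher number from compound 3 to compound 4 (0.30 log units; within the scatter) in this assay, so compound 3 and compound 4 cannot be told apart on this read-out. The same change on the core of compound 1 gives a step that cannot be read, as compound 1 and compound 2 both give only a limit: the limit of > 50000 nM in this assay, at which 2 of the 4 values shown sit. The series therefore holds a single readable instance of the change, which shows how it reads on the core of compound 3 only; it does not show that the step carries from one core to another with the same size, and the two cores cannot be compared on this point.

The compounds shown leave open whether a longer chain on the same oxygen, such as butanoyl or benzoyl, or a group bearing an amine or a carboxylic acid there, would give a number clearly apart from that of compound 3, 13800 nM, in this assay. Also open, on these data alone, is how acetyl reads on the other hydroxy groups of compound 3, and whether any such change on the core of compound 1 would give a number rather than a limit.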